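The compounds below may be only part of what the source reports. "The series", "measured", "known", "first", "only" and "open" are said of these compounds alone.

Measured so far in a functional assay on MCF7 cells (Homo sapiens) for antiproliferative activity, read by CellTiter-Glo, with a stated time of 5 days; on this read-out higher numbers stand for weaker inhibition and lower numbers for stronger inhibition

Compound 1 `CC1=C(c2cccc(O)c2)C(c2ccc(OC[C@@H](C)N3CCCC3)cc2)Oc2ccc(O)cc21` gives 0.2 nM
Compound 2 `CC1=C(c2cccc(O)c2)[C@H](c2ccc(OC[C@H](C)N3CC[C@@H](C)C3)cc2)Oc2ccc(O)cc21` gives 0.1 nM
Compound 3 `CC1=C(c2cccc(S(C)(=O)=O)c2)C(c2ccc(OC[C@H](C)N3CC[C@@H](C)C3)cc2)Oc2ccc(O)cc21` gives 4.3 nM

Compound 2 cannot be separated from compound 1, since their values lie within the scatter of each other. Compound 3 stands on a clearly higher number, beyond the scatter. The next compound is compound 4 `CC1=C(c2cccc(O)c2)C(c2ccc(OC[C@@H](C)N3CC[C@H](C)C3)cc2)Oc2ccc(O)cc21` and the change from compound 2 is this one: the two compounds have the same atoms and bonds; at least one stereo element is drawn with a configuration in one of them and without one in the other: 3 of 3 stereo elements differ; a stereocentre at a saturated ring carbon is drawn S in compound 2 and without a configuration in compound 4; a stereocentre at a saturated chain carbon is drawn S in compound 2 and R in compound 4; a stereocentre at a saturated ring carbon is drawn R in compound 2 and S in compound 4 and no value for it exists yet. Among the measured compounds shown here, no measured pair here shows the size of such a stereochemical step in this assay so the expectation is tentative: a modest move to a higher number, meaning weaker inhibition. The expected change is a 4.0-fold higher number from compound 2 to compound 4 (0.60 log units; beyond the scatter) and would lie modestly beyond the scatter. For compound 4 the estimated value is 0.4 nM with an expected range from 0.1 nM to 2 nM in this assay.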

Compound 4, half-maximal inhibitory concentration: 0.2 nM
Compound 4: middle estimate off by 2.0-fold (0.30 log units), on the high side; the measured number falls inside the stated range.
By their numbers in this assay, from the lowest: compounds 2, 1 and 4 (each within the scatter of the next); then compound 3.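

In this assay, the stereochemical change gives a 2.0-fold higher number from compound 2 to compound 4 (0.30 log units; within the scatter), so the three redrawn stereocentres together produce no separable shift in this assay. Methyl in place of hydrogen on a saturated ring carbon gives no change at the digits printed from compound 1 to compound 4 (within the scatter), showing that this added methyl leaves the number within the scatter. The stereochemical reading stays limited because of one point: the fact that one of compounds 2 and 4 is drawn with a defined configuration and the other without, at the place where they differ

The compounds shown leave open what each stereocentre contributes alone, as all three differ at once. They also leave open whether ethyl or hydroxymethyl in place of that methyl would keep the number within the scatter.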